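A Sulfur-Linked Change in a Cell Growth Series

The source may report more compounds than this note shows. Statements on the series, on what has been measured and on what is new or still open speak of the compounds shown alone.

Compound 1 `O=C(/C(=C\c1ccc(F)cc1C(F)(F)F)[S+]([O-])Cc1ccc(Cl)cc1)c1ccc(Cl)cc1` was tested in a functional assay on DU-145 cells (Homo sapiens) for inhibition, read by trypan blue exclusion, with a stated time of 96 h (a lower number here means a stronger inhibitor of growth, a higher number a weaker inhibitor of growth), where compound 1 gives 50000 nM. This is the higher of the two numbers in hand: compound 2 `O=C(/C(=C\c1ccc(Br)cc1)Sc1ccccc1Br)c1ccc(Br)cc1` gives 1000 nM, a far lower number, and the gap between compound 1 and compound 2 lies beyond the scatter of repeated measurements. Compound 3 `Cc1ccc(CS/C(=C/c2ccc(F)cc2C(F)(F)F)C(=O)c2ccc(Cl)cc2)cc1` has not yet been measured. It differs from compound 1 in one place: a group of 9 heavy atoms (8 carbon, 1 sulfur; one six-membered aromatic ring of carbon only) in place of a group of 10 heavy atoms (7 carbon, 1 oxygen, 1 sulfur, 1 chlorine; one six-membered aromatic ring of carbon only), on a double-bonded chain carbon bound to a carbonyl carbon and a double-bonded chain carbon The group that enters carries sulfur but no oxygen, as the count shows, and its carbon-only aromatic ring carries no chlorine. For the measured compounds named here, no measured pair shows this exact change, so its size can only be judged from what the two values show. Because compound 2 gives 1000 nM with a sulfur-linked side group and a far lower number than compound 1, compound 3 is expected to move in the same direction, by a 17-fold lower number from compound 1 to compound 3 (1.22 log units; beyond the scatter), a step beyond the scatter. The estimate for compound 3 in this assay is therefore 3000 nM, with a range from 500 nM to 20000 nM.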

Compound 3, concentration for 50% growth inhibition: 50000 nM
Beside the measured number, compound 3's estimate is 17-fold (1.22 log units) below it; measured number above the stated range.
By their numbers in this assay, from the lowest: compound 2; then compounds 1 and 3 (each within the scatter of the next).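

In this assay, placing (4-methylbenzyl)sulfanyl on a double-bonded chain carbon bound to a carbonyl carbon and a double-bonded chain carbon, in place of the oxygen- and chlorine-bearing group of compound 1, gives no change at the digits printed from compound 1 to compound 3 (within the scatter). For the compounds shown here, this is the first direct reading at this place, and it shows that this exchange of one sulfur-bearing group for another, with its carbon-only aromatic ring kept, leaves compound 1 and compound 3 indistinguishable in this measurement, so a sulfur-linked group of this kind does not by itself account for the lower number of compound 2, which differs from compound 1 in more than one place. No measurement shown here explains this result.

The exchange removes the oxygen and the chlorine together, so the compounds shown do not separate what each of these contributes at this place. As far as these compounds go, it also remains open whether an entirely different group here, such as an amine or a longer carbon chain, would give a number different from that of compound 1, and which of the several differences in compound 2 goes with its lower number.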